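Working notes on the step from compound 2 to compound 4

The source may report more compounds than this note shows. Statements on the series, on what has been measured and on what is new or still open speak of the compounds shown alone.

Three compounds have numbers in a functional assay on NCI-H1581 cells (Homo sapiens) for inhibition, read by MTT assay, with a stated time of 48 h, tested at 10 uM; on this read-out lower numbers stand for less inhibition and higher numbers for more inhibition at the one concentration tested (going by the name of the read-out). Compound 1 `COc1cc(Nc2cc(NC(=O)Nc3c(Cl)cccc3Cl)ncn2)cc(OC)c1` gives 68%. Compound 2 `COc1cc(NC(=O)Nc2cc(Nc3ccc(C)c(F)c3)ncn2)cc(OC)c1` gives 38%, and compound 3 `COc1cc(Nc2cc(NC(=O)Nc3c(Cl)cccc3Cl)ncn2)cc(C(F)(F)F)c1` gives 32.3%. Compound 2 thus holds the second highest of the three numbers: its nearest neighbour is compound 3, whose number lies within the scatter of it, while compound 1 stands well higher, beyond the scatter. Among the measured compounds shown here, the one single-point step among the measured compounds is a number 35.7 percentage points lower from compound 1 to compound 3 (beyond the scatter); it concerns the trifluoromethyl for methoxy exchange on an aromatic carbon and says nothing about the other aryl group.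

Compound 4 `COc1cc(NC(=O)Nc2cc(Nc3ccc(OC)c(I)c3)ncn2)cc(OC)c1` is not yet measured. It differs from compound 2 in one place: 3-iodo-4-methoxyphenyl in place of 3-fluoro-4-methylphenyl on a nitrogen on an aromatic ring. The change sits on a nitrogen on an aromatic ring whose other neighbours are aromatic carbon. For the measured compounds named here, no measured step touches this position, so the large step from compound 1 to compound 3 does not transfer to it. With nothing in the data to point either way, a step within the scatter is expected from compound 2 to compound 4 in this assay, namely a number 2 percentage points higher from compound 2 to compound 4 (within the scatter). Compound 4 is therefore estimated at 40%, with a range from 20% to 62%.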

Compound 4, a percentage reported as inhibition, at one concentration (the size of the read-out at that concentration, not a potency): 43%
Compound 4: the middle estimate sits 3 percentage points below what was measured; the range from low to high includes it.
By their numbers in this assay, from the lowest: compounds 3, 2 and 4 (each within the scatter of the next, the first and the last beyond it); then compound 1.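

In this assay, the first step read at this position is a number 5 percentage points higher from compound 2 to compound 4 (within the scatter), so replacing 3-fluoro-4-methylphenyl with 3-iodo-4-methoxyphenyl on a nitrogen on an aromatic ring leaves the read-out within the usual scatter, in contrast with the large step at the other aryl group from a number 35.7 percentage points lower from compound 1 to compound 3 (beyond the scatter). The exchange alters two substituents on the phenyl ring at once and brings in a hydrogen-bond acceptor, yet this single pair cannot separate the contributions of the two substituents, and the small net step could equally reflect little effect from either or two effects that offset each other. No supporting measurement is available to explain this result.

The compounds shown leave open how each substituent acts alone, since neither a 3-iodophenyl nor a 4-methoxyphenyl group appears at this position. They also leave open whether a more different group on that phenyl ring, such as a carboxylic acid or a dimethylamino group, would produce a step beyond the scatter.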